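The source may hold more compounds than are shown below. What is called first, only, known or untested is meant among the compounds shown, and "the series" means these compounds.

In a functional assay on KB cells (Homo sapiens) for antiproliferative activity, read by sulforhodamine B assay, with a stated time of 3 days (on this read-out lower numbers stand for an effect already at smaller amounts and higher numbers for an effect only at larger amounts of compound), compound 1 `CCC1=C(O)c2c(oc(-c3ccc(O)cc3)cc2=O)C(CC)(CC)C1=O` gives 20.6 uM and compound 3 `CCC1=C(O)c2c(oc(-c3ccc(C)cc3C)cc2=O)C(CC)(CC)C1=O` gives 41.2 uM, so compound 3 stands within the scatter of compound 1: the measured change is a 2.0-fold higher number from compound 1 to compound 3 (0.30 log units; within the scatter). Compound 2 `CCC1=C(O)c2c(oc(-c3ccc(SC)cc3)cc2=O)C(CC)(CC)C1=O` gives only a limit, > 52.1 uM. Compound 4 `CCC1=C(O)c2c(oc(-c3ccc(OC)c(C)c3)cc2=O)C(CC)(CC)C1=O` carries 4-methoxy-3-methylphenyl in place of the 2,4-dimethylphenyl of compound 3, on an aromatic carbon next to the ring oxygen: 4-methoxy-3-methylphenyl in place of 2,4-dimethylphenyl on an aromatic carbon. Two further steps changed the group at this same place. One is an at least 2.5-fold higher number from compound 1 to compound 2 (0.40 log units; beyond the scatter), which lies beyond the scatter and rests on a limit. The other is an at least 1.2-fold lower number from compound 2 to compound 3 (0.10 log units; that floor lies within the scatter), whose floor lies within the scatter. With these modest steps as a guide, the expected change is a 1.2-fold lower number from compound 3 to compound 4 (0.07 log units; within the scatter), with no shift beyond the scatter anticipated. For compound 4 the estimate is 35 uM, with an expected range from 15 uM to 60 uM.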

Compound 4, concentration for half-maximal effect: 28.5 uM
Estimate against measurement, compound 4: 1.2-fold (0.09 log units) above; low and high end bracket the measured number.
By their numbers in this assay, from the lowest: compounds 1, 4 and 3 (each within the scatter of the next). At a limit, above all of these: compound 2.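

In this assay, 4-methoxy-3-methylphenyl on this aromatic carbon next to the ring oxygen stays within the scatter of both 2,4-dimethylphenyl and 4-hydroxyphenyl, with a 1.4-fold lower number from compound 3 to compound 4 (0.16 log units; within the scatter) and a 1.4-fold higher number from compound 1 to compound 4 (0.14 log units; within the scatter). This change therefore separates none of these three compounds. Against compound 2 the result is an at least 1.8-fold lower number from compound 2 to compound 4 (0.26 log units; that floor lies within the scatter), and compound 2 gives only a limit: the limit of > 52.1 uM in this assay, at which 1 of the 4 values shown sits.

Whether an amine, a carboxylic acid or a longer chain on this phenyl ring would move the number beyond the scatter of these compounds stays open.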